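The source may hold more compounds than are shown below. What is called first, only, known or untested is meant among the compounds shown, and "the series" means these compounds.

Compound 1 `CCOC(=O)/C=C/c1ccncc1-c1ccc2ccccc2c1` and compound 2 `CCOC(=O)/C=C/c1ccncc1-c1ccc2c(ccn2C)c1` share a carbonyl-bearing chain but differ in their cores. In an assay on a protein complex for inhibition of CDK8/Cyclin C (Homo sapiens), with a stated time of 1 h (a lower number here means a stronger inhibitor, a higher number a weaker inhibitor), compound 1 gives 53.3 nM, the lower of the two numbers, and compound 2 gives 144 nM, a higher number that lies beyond the usual scatter of repeated measurements. For the measured compounds named here, compound 3 `O=C(/C=C/c1ccncc1-c1ccc2ccccc2c1)NC1CC1` has not yet been measured; it keeps the core of compound 1, and the single change is cyclopropylamino in place of ethoxy on a carbonyl carbon. Going by the values given here, no measured pair shows what this change does, so the expectation rests on compound 1 alone. With cyclopropylcarbamoyl in place of ethoxycarbonyl, the number in this assay is expected to stay close to that of compound 1, with at most a modest move in either direction, so the estimated step of a 1.3-fold lower number from compound 1 to compound 3 (0.12 log units; within the scatter) is small. Compound 3 is therefore estimated at 40 nM, within a range from 10 nM to 160 nM.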

Compound 3, half-maximal inhibitory concentration: 40.1 nM
Compound 3: middle estimate off by 1.0-fold (0.00 log units), on the low side; the measured number falls inside the stated range.
By their numbers in this assay, from the lowest: compounds 3 and 1 (each within the scatter of the next); then compound 2.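

In this assay, cyclopropylamino in place of ethoxy on a carbonyl carbon gives a 1.3-fold lower number from compound 1 to compound 3 (0.12 log units; within the scatter), so the two compounds cannot be told apart. For the compounds shown here, this is the first sign that this position can take a different group without a clear loss: ethoxycarbonyl gives way to cyclopropylcarbamoyl, which adds a three-membered ring and a hydrogen-bond donor, and the number holds. Nothing available explains why the number holds.

Only one replacement at this carbonyl carbon is shown, so it remains open whether a carboxylic acid, a dimethylamino group or a longer chain there would shift the number beyond the scatter. Going by these compounds, it also remains open whether cyclopropylcarbamoyl would behave the same way on the core of compound 2.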